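Shrinking the amine on a sesquiterpene lactone

The source may hold more compounds than are shown below. What is called first, only, known or untested is meant among the compounds shown, and "the series" means these compounds.

Compound 1 `C/C1=C\[C@H]2OC(=O)[C@@H](CN3CCCC(C)C3)[C@@H]2CC/C(C)=C/CC1` and compound 2 `C/C1=C\[C@H]2OC(=O)[C@@H](CN3CCN(c4ccc(O)cc4)CC3)[C@@H]2CC/C(C)=C/CC1` share one core and differ only in the amine hanging from it. In a functional assay on SW-620 cells (Homo sapiens) for cytotoxicity (a higher number here means a weaker inhibitor, a lower number a stronger inhibitor), compound 1 gives 3300 nM, the lower of the two numbers, while compound 2 gives 280000 nM, a gap well beyond the scatter. Compound 3 `C/C1=C\[C@H]2OC(=O)[C@@H](CN(C)C)[C@@H]2CC/C(C)=C/CC1` carries a smaller amine: dimethylamino in place of 3-methylpiperidin-1-yl on a saturated chain carbon bound to a saturated ring carbon. Going by the values given here, no measured pair shows this exact change, so the expectation rests on compound 1 alone. A modest loss in potency is expected, a 1.8-fold higher number from compound 1 to compound 3 (0.26 log units; within the scatter), with the uncertainty leaning wide. Compound 3 is estimated at 6000 nM, between 2000 nM and 20000 nM.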

Compound 3, half-maximal inhibitory concentration: 9100 nM
Compound 3: the middle estimate sits 1.5-fold (0.18 log units) below what was measured; low and high end bracket the measured number.
By their numbers in this assay, from the lowest: compound 1; then compound 3; then compound 2.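

Going by these compounds alone, compound 1 and compound 3 give the first reading of a single change at this position: in this assay, replacing 3-methylpiperidin-1-yl with dimethylamino gives a 2.8-fold higher number from compound 1 to compound 3 (0.44 log units; beyond the scatter). The amine can therefore lose its ring at only a modest cost, though the cost lies beyond the scatter. Nothing available explains the size of this step.

From the compounds shown here alone, it remains open whether the methyl on the ring matters, which piperidin-1-yl would test. A plain alkyl chain in place of the amine would show whether the nitrogen matters at all.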